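Extending the Side Chain of Compound 2 by Seven Carbons

A few compounds are considered here, and "the series" means these few. Any claim that something is new, unique, unknown or untested is made for them only; others in the source may bear on it.

Compound 1 `CCCCCCCCCCCCCC[C@@H](O)[C@@H](O)[C@H](CO)n1cc(CCCC)nn1` gives 12900 nM in a functional assay on HCT-116 cells (Homo sapiens) for cytotoxicity, read by sulforhodamine B assay; on this read-out higher numbers stand for an effect only at larger amounts of compound and lower numbers for an effect already at smaller amounts.
Compound 2 `CCCCCCCCCCCCCC[C@@H](O)[C@@H](O)[C@H](CO)n1cc(CCCCCC)nn1` gives 12000 nM in this assay.
Compound 3 `CCCCCCCCCCCCC/C=C/[C@@H](O)[C@H](CO)NC(C)=O` gives 24500 nM in this assay.

Compound 2 shows the lowest number of the three, though compound 1 sits within the scatter of it; compound 3 stands higher, beyond the scatter. Compound 4 `CCCCCCCCCCCCCC[C@@H](O)[C@@H](O)[C@H](CO)n1cc(CCCCCCCCCCCCC)nn1` is not yet measured. It differs from compound 2 by heptyl in place of hydrogen on a saturated chain carbon, six bonds along the chain from an aromatic carbon. For the measured compounds named here, the only measured step that touches this side chain is a 1.1-fold lower number from compound 1 to compound 2 (0.03 log units; within the scatter), where a shorter extension at the same chain changed nothing beyond the scatter. On that basis, a further lengthening is expected to leave the number about where compound 2 stands, with no change at the digits printed from compound 2 to compound 4 (within the scatter) as the expected step. Compound 4 is therefore estimated at 12000 nM, within a range from 5000 nM to 30000 nM.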

Compound 4, half-maximal effective concentration: > 50000 nM
Compound 4: only a limit was reported; the forecaster's own chance of this, stated with the estimate: 10%; middle value at least 4.1-fold (0.61 log units) from the limit.
By their numbers in this assay, from the lowest: compounds 2, 1 and 3 (each within the scatter of the next, the first and the last beyond it). At a limit, above all of these: compound 4.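

Compound 4 gives only a limit in this assay: > 50000 nM. This side chain is therefore not indifferent to length: the record shows an at least 4.1-fold higher number from compound 2 to compound 4 (0.61 log units; beyond the scatter), and an at least 3.8-fold higher number from compound 1 to compound 4 (0.58 log units; beyond the scatter), so an effect now needs larger amounts of compound. The small extension, a 1.1-fold lower number from compound 1 to compound 2 (0.03 log units; within the scatter), gave no sign of this.

From the compounds shown here alone, whether an octyl or a decyl chain at this place would stay close to compound 2 or already behave like compound 4 remains open. Going by these compounds, the full size of the step also remains open.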